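From Ethyl to tert-Butyl on a Shared Core

A few compounds are considered here, and "the series" means these few. Any claim that something is new, unique, unknown or untested is made for them only; others in the source may bear on it.

Of the compounds shown here, three built on one shared core have been tested in a functional assay on HCC827 cells (Homo sapiens) for inhibition, read by MTT assay, with a stated time of 48 h, tested at 10 uM; a lower number here means less inhibition, a higher number more inhibition at the concentration tested (going by the name of the read-out). Compound 1 `COc1cc(NC(=O)Nc2cc(Nc3ccc(OC)c(C)c3)ncn2)cc(OC)c1` gives 48.3% in this assay. Compound 2 `CCc1ccc(Nc2cc(NC(=O)Nc3c(Cl)cccc3Cl)ncn2)cc1` gives 58% in this assay. Compound 3 `CCc1cccc(Nc2cc(NC(=O)Nc3cc(OC)cc(OC)c3)ncn2)c1` gives 52.6% in this assay. Compound 3 stands second highest of the three, with compound 1 nearest and compound 2 furthest, yet both gaps lie within the usual scatter, so the three cannot be ranked on these numbers. For the measured compounds named here, the only measured step between compounds that differ in a single place, a number 4.3 percentage points higher from compound 1 to compound 3 (within the scatter), is likewise within the scatter.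

Compound 4 `COc1cc(NC(=O)Nc2cc(Nc3cccc(C(C)(C)C)c3)ncn2)cc(OC)c1` has not yet been measured. It differs from compound 3 in one place: tert-butyl in place of ethyl on an aromatic carbon. Going by the values given here, the change sits on an aromatic carbon of a six-membered aromatic ring of carbon only, the part of the molecule that was also exchanged in the one measured step, and that step stayed within the scatter. Among the compounds with values here, no measured pair swaps ethyl for tert-butyl, so nothing bears on this exact change directly. The expected change in this assay is therefore small, with no direction beyond the scatter, estimated as a number 0.4 percentage points higher from compound 3 to compound 4 (within the scatter). Compound 4 is estimated at 53%, with a range from 40% to 66%.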

Compound 4, a percentage reported as inhibition, at one concentration (the size of the read-out at that concentration, not a potency): 48.7%
Estimate against measurement, compound 4: 4.3 percentage points above, and the stated range covers the measured number.
By their numbers in this assay, from the lowest: compounds 1, 4, 3 and 2 (each within the scatter of the next).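

For the compounds shown here, replacing ethyl with tert-butyl on this aromatic carbon, meta to a large group, tests the alkyl group itself for the first time: the chain grows from 2 to 4 carbons, and this assay shows a number 3.9 percentage points lower from compound 3 to compound 4 (within the scatter). A second comparison, with 3-(tert-butyl)phenyl in place of 4-methoxy-3-methylphenyl on the nitrogen, shows a number 0.4 percentage points higher from compound 1 to compound 4 (within the scatter), and together with a number 4.3 percentage points higher from compound 1 to compound 3 (within the scatter) it means that the three groups compared at this site cannot be told apart on these numbers. No measured information is available to explain these results.

On these data alone, every step at this site so far stays within the scatter, so it remains open whether a group of a different kind, such as an amine or a carboxylic acid, in place of the tert-butyl would produce a readable difference. Each number also comes from a single tested concentration, which leaves open how these compounds compare in potency.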